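Hydroxyphenyl in place of dimethoxyphenyl on one arylidene arm

A few compounds are considered here, and "the series" means these few. Any claim that something is new, unique, unknown or untested is made for them only; others in the source may bear on it.

Compound 1 `COc1cccc(/C=C2\CCC/C(=C\c3cc(OC)c(OC)c(OC)c3)C2=O)c1OC` stands at the top of the two numbers in a functional assay on RKO cells (Homo sapiens) for antiproliferative activity, read by MTT assay, with a stated time of 72 h (on this read-out higher numbers stand for weaker inhibition and lower numbers for stronger inhibition), at 3600 nM, though compound 2 `COc1cc(/C=C2\CCC/C(=C\c3ccc(O)c(O)c3)C2=O)cc(OC)c1OC` with 3100 nM lies within the scatter of it. Among the measured compounds shown here, the one measured step on this arm, a 1.2-fold lower number from compound 1 to compound 2 (0.06 log units; within the scatter), stayed within the scatter. Compound 3 `COc1cc(/C=C2\CCC/C(=C\c3cccc(O)c3)C2=O)cc(OC)c1OC` differs from compound 1 by 3-hydroxyphenyl in place of 2,3-dimethoxyphenyl on a double-bonded chain carbon bound to a double-bonded ring carbon. For the measured compounds named here, only that step bears on it, and no other ring at this position has been measured. No step beyond the scatter is therefore expected. Compound 3 is estimated at 3500 nM (1500 nM to 8000 nM), a step of a 1.0-fold lower number from compound 1 to compound 3 (0.01 log units; within the scatter).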

Compound 3, half-maximal inhibitory concentration: 6500 nM
Compound 3: middle estimate off by 1.9-fold (0.27 log units), on the low side; the range from low to high includes it.
By their numbers in this assay, from the lowest: compounds 2, 1 and 3 (each within the scatter of the next, the first and the last beyond it).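

On this arm the ring's substitution now shows an effect in this assay: hydrogen in place of hydroxy on an aromatic carbon gives a 2.1-fold higher number from compound 2 to compound 3 (0.32 log units; beyond the scatter) and is the only step shown beyond the scatter, though a modest one. The change to 3-hydroxyphenyl from 2,3-dimethoxyphenyl gives a 1.8-fold higher number from compound 1 to compound 3 (0.26 log units; within the scatter) and stays within the scatter, so compound 3 is not separated from compound 1 . No evidence on hand accounts for either step.

Still open, from the compounds shown here alone, is how an amine or a carboxylic acid in place of that hydroxy would read in this assay and whether the same hydroxy step holds with other groups on the second arm.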